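Sulfonyl series: oxetane, ether and phenylcarbinol side chains

A few compounds are considered here, and "the series" means these few. Any claim that something is new, unique, unknown or untested is made for them only; others in the source may bear on it.

Measured so far in an assay on isolated protein for inhibition of Aromatase (Homo sapiens), tested at 1 uM; on this read-out lower numbers stand for less inhibition and higher numbers for more inhibition at the one concentration tested (going by the name of the read-out):
compound 1 `C[C@@H](c1ccc(Cl)cc1)N1Cc2cncn2C(CC2(C)COC2)S1(=O)=O` gives 35%
compound 2 `C[C@@H](c1ccc(Cl)cc1)N1Cc2cncn2C(C[C@@H](O)c2ccccc2)S1(=O)=O` gives 6%
compound 3 `CC(C)OCC1n2cncc2CN([C@@H](C)c2ccc(Cl)cc2)S1(=O)=O` gives 23%

Compound 3 stands second highest of the three numbers in this assay. Its nearest neighbour is compound 1, a number 12 percentage points lower from compound 1 to compound 3 (beyond the scatter); its furthest is compound 2, a number 17 percentage points higher from compound 2 to compound 3 (beyond the scatter).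

Compound 4 `C[C@@H](c1ccc(Cl)cc1)N1Cc2cncn2C(C[C@H](O)c2ccccc2)S1(=O)=O` has not yet been measured. The change from compound 3 is: hydroxy(phenyl)methyl in place of isopropoxy on a saturated chain carbon bound to a saturated ring carbon. For the measured compounds named here, two measured steps bear on it. The step of a number 17 percentage points higher from compound 2 to compound 3 (beyond the scatter) is the same exchange run backwards, the only difference being the configuration at the stereocentre of the hydroxy(phenyl)methyl group; compound 2 carries the other configuration. The step of a number 29 percentage points lower from compound 1 to compound 2 (beyond the scatter) likewise shows hydroxy(phenyl)methyl entering, with a larger fall from a higher start. Both point the same way, so in this assay the expectation for compound 4 is a modest fall beyond the scatter, a number 13 percentage points lower from compound 3 to compound 4 (beyond the scatter), landing near the number compound 2 shows. Compound 4 is therefore estimated at 10%, with a range from 0% to 25%; whether the change of configuration moves the number is not knowable from the compounds in hand.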

Compound 4, a percentage reported as inhibition, at one concentration (the size of the read-out at that concentration, not a potency): 6%
Beside the measured number, compound 4's estimate is 4 percentage points above it; measured number inside the range.
By their numbers in this assay, from the lowest: compounds 2 and 4 (each within the scatter of the next); then compound 3; then compound 1.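

In this assay, the configuration at the stereocentre of the hydroxy(phenyl)methyl group makes no readable difference, the comparison giving no change at the digits printed from compound 2 to compound 4 (within the scatter), so the low number of compound 2 is not tied to one configuration at this saturated chain carbon. Compound 4 therefore repeats the fall seen on bringing in hydroxy(phenyl)methyl, showing a number 17 percentage points lower from compound 3 to compound 4 (beyond the scatter) against isopropoxy and a number 29 percentage points lower from compound 1 to compound 4 (beyond the scatter) against 3-methyloxetan-3-yl, and at this position the fall holds for both drawn configurations. The stereo comparison carries one caveat in how the pair is recorded: the fact that one of compounds 2 and 4 is drawn with a defined configuration and the other without, at the place where they differ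

The compounds shown do not separate the part played by the phenyl ring from that of the hydroxy group, and a 2-phenylethyl chain without the hydroxy, or an amine in place of the hydroxy, would pull the two apart. Going by these compounds, how far the side chain can go upward in this assay also stays open, since the highest number here belongs to a single group, 3-methyloxetan-3-yl, with no close relative such as an unsubstituted oxetane or a longer ether chain to set beside it.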